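A few compounds are considered here, and "the series" means these few. Any claim that something is new, unique, unknown or untested is made for them only; others in the source may bear on it.

Of the compounds shown here, three built on a shared core have been tested in a functional assay on cells (Platelet, Homo sapiens) for inhibition; on this read-out lower numbers stand for stronger inhibition and higher numbers for weaker inhibition. In this assay compound 1 `CCOC(=O)c1cccc(-c2n[nH]c3ccccc23)c1` returns only a limit, > 10000 nM. Compound 2 `CCOC(=O)c1ccc(-c2nn(Cc3ccccc3F)c3ccccc23)cc1` likewise gives a limit, > 10000 nM. Compound 3 `CCOC(=O)c1ccc(-c2nn(Cc3ccccn3)c3ccccc23)cc1` also stops at a limit, > 10000 nM, so compound 3 stands at the same edge as the other two, with no number of its own. The step that the two limits leave unreadable from compound 2 to compound 3 is accordingly not readable. Compound 4 `CCCCn1nc(-c2ccc(C(=O)OCC)cc2)c2ccccc21` differs from compound 3 by propyl in place of pyridin-2-yl on a saturated chain carbon bound to an aromatic nitrogen. For the measured compounds named here, no measured step bears on this change, and because the limit of > 10000 nM in this assay, at which 3 of the 3 values shown sit, gathers every value at the limit, no direction can be drawn. The step that the limit leaves unreadable from compound 3 to compound 4 is expected to stay within the scatter. Compound 4 is therefore estimated at 30000 nM, in a range from 10000 nM to 100000 nM.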

Compound 4, half-maximal inhibitory concentration: > 10000 nM
Compound 4 was reported as a limit (the forecaster's own chance of this, stated with the estimate: 85%); the middle value does not contradict the limit.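

Compound 4 also returns only a limit, > 10000 nM, in this assay, so the steps from compound 2 and compound 3 to compound 4 cannot be read. The compounds shown leave open which structural change, if any, would give a measurable inhibitory value, as all share one edge: the limit of > 10000 nM in this assay, at which 4 of the 4 values shown sit.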